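Fluoro to chloro on the outer phenyl, two cores

This account rests on a few compounds, and the source may have more. Where it says the series, first, only, none or still open, it means among the compounds named here.

In a functional assay on HT-29 cells (Homo sapiens) for cytotoxicity, read by MTT assay, with a stated time of 72 h (a lower number here means a stronger inhibitor, a higher number a weaker inhibitor), compound 1 `CN(C)CCNc1nc(-c2ccc(NC(=O)Nc3ccccc3F)cc2)nc2ccsc12` gives 510 nM. Compound 2 `CN(C)CCNc1nc(-c2ccc(NC(=O)Nc3ccccc3Cl)cc2)nc2ccsc12` gives 310 nM in this assay and differs from compound 1 by chloro in place of fluoro on an aromatic carbon, which produced a 1.6-fold lower number from compound 1 to compound 2 (0.22 log units; within the scatter). Compound 3 `CCN(CC)CCNc1nc(-c2ccc(NC(=O)Nc3ccc(F)cc3)cc2)nc2c(Cl)c(Cl)sc12` carries another core; the difference between the two cores is not broken down here. In this assay compound 3 gives 650 nM, a number that lies beyond the scatter against compound 2 but within it against compound 1. Compound 4 `CCN(CC)CCNc1nc(-c2ccc(NC(=O)Nc3ccc(Cl)cc3)cc2)nc2c(Cl)c(Cl)sc12` is compound 3 with chloro in place of fluoro on an aromatic carbon. For the measured compounds named here, this is the same kind of change as the one from compound 1 to compound 2, not the same change: there the chloro stands ortho to a large group, here it stands para to a large group, and the core is different. Going by the values given here, only one measured pair shows this change, so the expectation rests on that pair alone. A step of a 1.4-fold lower number from compound 3 to compound 4 (0.16 log units; within the scatter) is expected, because a 1.6-fold lower number from compound 1 to compound 2 (0.22 log units; within the scatter) stayed within the scatter and the present change is of the same kind. For compound 4 the estimate is 450 nM, expected to fall between 200 nM and 1000 nM.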

Compound 4, half-maximal inhibitory concentration: 430 nM
Beside the measured number, compound 4's estimate is 1.0-fold (0.02 log units) above it; measured number inside the range.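

In this assay, chloro in place of fluoro gives a 1.5-fold lower number from compound 3 to compound 4 (0.18 log units; within the scatter), and the steps on the two cores agree: the same change on two cores in this assay, a 1.6-fold lower number (0.22 log units; within the scatter) from compound 1 to compound 2 and a 1.5-fold lower number (0.18 log units; within the scatter) from compound 3 to compound 4, 1.1-fold (0.04 log units) apart, within the scatter of two such steps

Neither step lies beyond the scatter, so the change carries from one core to the other only in the limited sense that it leaves the number within the scatter on both. This does not show that the core has no bearing on the change, since the two pairs also differ in where the halogen stands, para to a large group only in compound 3 and compound 4, and any difference between cores smaller than the scatter would stay hidden.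

Open, on these data alone, is how a bromo, methoxy or trifluoromethyl group in that place on the outer phenyl would read on either core, and whether any such group would give a step beyond the scatter. Also open, as far as these compounds go, is whether the two steps would still agree with a morpholine in place of the amine at the end of the side chain.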